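A Phenyl Replaces Pentafluoroethyl on the Shared Core

This account rests on a few compounds, and the source may have more. Where it says the series, first, only, none or still open, it means among the compounds named here.

Among the compounds with values here, of the three compounds already measured in an assay on Jurkat cells for activation of nuclear factor NF-kappa-B complex (Homo sapiens) (on this read-out lower numbers stand for stronger inhibition and higher numbers for weaker inhibition), compound 1 `O=C(Nc1cc(C(F)(F)F)cc(C(F)(F)F)c1)c1cnc(Cl)nc1C(F)(F)C(F)(F)F` is the only one that gives a number: compound 1 shows 800 nM. Compound 2 `O=C(Nc1cc(C(F)(F)F)cc(C(F)(F)F)c1)c1cnc(C(F)(F)F)nc1Cl` sits at the limit of this assay, reported as > 10000 nM. Compound 3 `O=C(Nc1cc(C(F)(F)F)cc(C(F)(F)F)c1)c1cnc(C(F)(F)F)nc1C(F)(F)F` likewise sits at the limit, reported as > 10000 nM. Within the data shown here, the one step between measured compounds that differ in a single place, a step that the two limits leave unreadable from compound 2 to compound 3, cannot be read because both of its ends lie at the limit of > 10000 nM in this assay, at which 2 of the 3 values shown sit.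

Compound 4 `O=C(Nc1cc(C(F)(F)F)cc(C(F)(F)F)c1)c1cnc(Cl)nc1-c1ccccc1` differs from compound 1 by phenyl in place of 1,1,2,2,2-pentafluoroethyl on an aromatic carbon. Among the measured compounds shown here, no measured step touches this kind of exchange, and the only step that exists, from compound 2 to compound 3, concerns a chloro and a trifluoromethyl rather than a phenyl, so it gives no direction. With compound 1 at 800 nM as the sole anchor, the step of a 1.9-fold higher number from compound 1 to compound 4 (0.27 log units; within the scatter) is expected to stay inside the usual scatter. Compound 4 is therefore estimated at 1500 nM, with a range from 300 nM to 10000 nM.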

Compound 4, half-maximal inhibitory concentration: 400 nM
Compound 4: the middle estimate sits 3.8-fold (0.57 log units) above what was measured; low and high end bracket the measured number.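

In this assay, putting phenyl in place of 1,1,2,2,2-pentafluoroethyl on the aromatic carbon next to the ring nitrogen gives a 2.0-fold lower number from compound 1 to compound 4 (0.30 log units; within the scatter). This position therefore carries either a six-membered aromatic ring of carbon only or a fluorinated chain with the read-out staying within the usual scatter, and compound 4 is the second compound in the set to give a number rather than a limit. Nothing measured here gives a reason for this outcome.

From the compounds shown here alone, it remains open whether an amine, a methyl group or a saturated ring such as cyclohexyl would hold at this position, or how a phenyl bearing a methoxy or fluoro group would read. Going by these compounds, it also remains open whether phenyl would hold there with trifluoromethyl in place of the chloro group on the shared core.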